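A few compounds are considered here, and "the series" means these few. Any claim that something is new, unique, unknown or untested is made for them only; others in the source may bear on it.

Measured compounds in an ADME assay (liver) for metabolic stability, with Liver microsome (Rattus norvegicus) as the target, using microsomes and NADPH, with a stated time of 30 min, tested at 1 uM; a higher number here means faster removal of the compound, a lower number slower removal:
Compound 1, `Nc1ccc(S(=O)(=O)N2CCN(c3ncc(C(O)(C(F)(F)F)C(F)(F)F)cc3C#CCCO)CC2)cn1`: compound 1 gives 68 mL.min-1.g-1.
Compound 2, `Cc1csc(-c2cc(C(O)(C(F)(F)F)C(F)(F)F)cnc2N2CCN(S(=O)(=O)c3ccc(N)nc3)CC2)c1`: compound 2 gives 399 mL.min-1.g-1.
Compound 3, `Nc1ccc(S(=O)(=O)N2CCN(c3ncc(C(O)(C(F)(F)F)C(F)(F)F)cc3-c3cccc(F)c3)CC2)cn1`: compound 3 gives 52 mL.min-1.g-1.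

Compound 3 sits at the lowest number of the three in this assay. Its nearest neighbour is compound 1, the gap being a 1.3-fold lower number from compound 1 to compound 3 (0.12 log units; within the scatter), which leaves the two compounds indistinguishable. Compound 2 lies furthest away: a 7.7-fold lower number from compound 2 to compound 3 (0.88 log units; beyond the scatter).

Compound 4, `Nc1ccc(S(=O)(=O)N2CCN(c3ncc(C(O)(C(F)(F)F)C(F)(F)F)cc3-c3ccc4sccc4c3)CC2)cn1`, has not yet been measured in this assay. Its difference from compound 3: 1-benzothiophen-5-yl in place of 3-fluorophenyl on an aromatic carbon. The group that enters carries a five-membered aromatic ring with 1 hetero atom, as does the 4-methylthiophen-2-yl group of compound 2. The step that bears most directly on the change is therefore a 7.7-fold lower number from compound 2 to compound 3 (0.88 log units; beyond the scatter), in which the compound bearing the five-membered heteroaromatic group sat at the higher number. The step of a 5.9-fold higher number from compound 1 to compound 2 (0.77 log units; beyond the scatter) points the same way. The step of a 1.3-fold lower number from compound 1 to compound 3 (0.12 log units; within the scatter) shows that a six-membered aromatic ring of carbon only gives a number close to that of the 4-hydroxybut-1-yn-1-yl group. For compound 4 a rise in this assay beyond the scatter is expected, though the entering group also keeps a six-membered aromatic ring of carbon only, so a smaller rise than that seen with compound 2 is expected: a 2.9-fold higher number from compound 3 to compound 4 (0.46 log units; beyond the scatter). Compound 4 is estimated at 150 mL.min-1.g-1, with a range of 60 mL.min-1.g-1 to 400 mL.min-1.g-1.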

Compound 4, intrinsic clearance in microsomes: 487 mL.min-1.g-1
For compound 4 the middle estimate is 3.2-fold (0.51 log units) below the measured one; measured number above the stated range.
By their numbers in this assay, from the lowest: compounds 3 and 1 (each within the scatter of the next); then compounds 2 and 4 (each within the scatter of the next).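

At this position on the shared core, a six-membered aromatic ring of carbon only in the entering group does not keep the number near that of compound 3: in this assay, 1-benzothiophen-5-yl in place of 3-fluorophenyl gives the step (  a 9.4-fold higher number from compound 3 to compound 4 (0.97 log units; beyond the scatter)). The five-membered aromatic ring with 1 hetero atom now appears in two different groups at this position, and these cannot be told apart (  a 1.2-fold higher number from compound 2 to compound 4 (0.09 log units; within the scatter)), while the 1-benzothiophen-5-yl group also stands clearly apart from 4-hydroxybut-1-yn-1-yl (  a 7.2-fold higher number from compound 1 to compound 4 (0.86 log units; beyond the scatter)). Among the four compounds, both groups carrying that five-membered ring sit at the high end and both groups without it at the low end, with no compound going against this, so the added six-membered ring of compound 4 does not offset the five-membered ring here.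

On these data alone, how a naphthalen-2-yl group, with two six-membered aromatic rings of carbon only, or a furan-2-yl group would read at this position remains open, so ring size and the sulfur atom are not separated. Nothing shown explains the rise.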